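Phenyl in place of 3-chloro-4-fluorophenyl in a cytotoxicity series

The source may hold more compounds than are shown below. What is called first, only, known or untested is meant among the compounds shown, and "the series" means these compounds.

Compound 1 `CC(O)(CSc1ccccc1)c1nc(-c2ccccc2)no1`: > 100000 nM (a limit of the assay)
Compound 2 `CC(O)(CSc1ccccc1)c1nc(-c2ccc(F)c(Cl)c2)no1`: 5500 nM
Compound 3 `CC(O)(CS(=O)(=O)c1ccc(F)cc1)c1nc(-c2ccc(F)c(Cl)c2)no1`: > 100000 nM (a limit of the assay)

In a functional assay on DU-145 cells (Homo sapiens) for cytotoxicity, read by MTT assay (on this read-out lower numbers stand for stronger inhibition and higher numbers for weaker inhibition), compound 2 gives 5500 nM. Compound 1 gives > 100000 nM, which is a limit of the assay and not a number. Compound 3 likewise gives > 100000 nM, again a limit of the assay. Compound 1 differs from compound 2 by phenyl in place of 3-chloro-4-fluorophenyl on an aromatic carbon, and this change brings an at least 18-fold higher number from compound 2 to compound 1 (1.25 log units; beyond the scatter), a rise that ends at the limit of > 100000 nM in this assay, at which 2 of the 3 values shown sit. Compound 3 and compound 2 differ in more than one place, and the difference between the two cores is not broken down here. The unmeasured compound 4 `CC(O)(CS(=O)(=O)c1ccc(F)cc1)c1nc(-c2ccccc2)no1` differs from compound 3 by phenyl in place of 3-chloro-4-fluorophenyl on an aromatic carbon, the same change as from compound 2 to compound 1. Because compound 3 already sits at the limit of > 100000 nM in this assay, at which 2 of the 3 values shown sit, the earlier step toward weaker inhibition gives no room for compound 4 to be reported as a number. The expected step is a step that the limit leaves unreadable from compound 3 to compound 4, which would leave compound 4 at the limit. Compound 4 is therefore estimated at about 300000 nM, with a range from 100000 nM to 2000000 nM.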

Compound 4, half-maximal inhibitory concentration: > 100000 nM
Compound 4: a limit, no number (the forecaster's own chance of this, stated with the estimate: 95%); the middle value is on the limit's open side.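

Going by these compounds alone, compound 3 and compound 4 both stop at a limit of the assay and not at a number, so no step between them can be read for phenyl in place of 3-chloro-4-fluorophenyl: the limit of > 100000 nM in this assay, at which 3 of the 4 values shown sit. In this assay the compounds shown leave open how far apart compound 3 and compound 4 truly lie.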